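Adding a Methyl to the Five-Membered Ring

This account rests on a few compounds, and the source may have more. Where it says the series, first, only, none or still open, it means among the compounds named here.

Of the compounds shown here, three have been measured in an assay for inhibition of acyl-CoA:cholesterol acyltransferase (Oryctolagus cuniculus), using microsomes; on this read-out lower numbers stand for stronger inhibition and higher numbers for weaker inhibition. Compound 2 `CCCCCNC(=O)Nc1c(OCCCn2cnc(-c3ccccc3)c2)cccc1N(C)C` gives 31 nM, the lowest of the three numbers; compound 1 `CCCCNC(=O)Nc1c(OCCCn2cnc(-c3ccccc3)c2)cccc1N(C)C` gives 140 nM and compound 3 `CCCCCCNc1c(OCCCn2cnc(-c3ccccc3)c2)cccc1N(C)C` gives 11000 nM. The measured steps, a 4.5-fold lower number from compound 1 to compound 2 (0.65 log units; beyond the scatter), a 79-fold higher number from compound 1 to compound 3 (1.90 log units; beyond the scatter) and a 350-fold higher number from compound 2 to compound 3 (2.55 log units; beyond the scatter), all alter the chain or the group attached to the nitrogen on the aromatic ring. Compound 4 `CCCCCNC(=O)Nc1c(OCCCn2cnc(-c3ccccc3)c2C)cccc1N(C)C` differs from compound 2 in another part of the shared core: methyl in place of hydrogen on an aromatic carbon. Going by the values given here, no measured step touches that position, and the measured data give no direct guide to it. Lacking such a guide, the expected step is one that stays within the scatter, no change at the digits printed from compound 2 to compound 4 (within the scatter). Compound 4 is therefore estimated at 31 nM, within a range from 10 nM to 100 nM.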

Compound 4, half-maximal inhibitory concentration: 43 nM
For compound 4 the middle estimate is 1.4-fold (0.14 log units) below the measured one; measured number inside the range.
By their numbers in this assay, from the lowest: compounds 2 and 4 (each within the scatter of the next); then compound 1; then compound 3.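

In this assay the methyl on this aromatic carbon of the five-membered ring gives a 1.4-fold higher number from compound 2 to compound 4 (0.14 log units; within the scatter) and so compound 2 and compound 4 cannot be told apart. Going by these compounds alone, this is the first reading at this position, and it shows that the shared core can carry this one added methyl here without a step beyond the scatter. No measured information accounts for this result. Going by these compounds, what stays open is how an ethyl, a phenyl or an amine at the same carbon would read. Also open, on these data alone, is whether the methyl gives a similar step with the butylcarbamoyl group of compound 1.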